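A few compounds are considered here, and "the series" means these few. Any claim that something is new, unique, unknown or untested is made for them only; others in the source may bear on it.

Three compounds sharing one core have numbers in a functional assay on HeLa cells (Homo sapiens) for cytotoxicity, read by MTT assay; on this read-out higher numbers stand for weaker inhibition and lower numbers for stronger inhibition. There compound 1 (`CC(C)=CC[C@@H](OC[C@@H](C)O)C1=CC(=O)c2c(O)ccc(O)c2C1=O`) gives 22500 nM, compound 2 (`CCCCC(CC(=O)O[C@H](CC=C(C)C)C1=CC(=O)c2c(O)ccc(O)c2C1=O)OC(C)=O`) gives 73500 nM and compound 3 (`CCC(CO[C@H](CC=C(C)C)C1=CC(=O)c2c(O)ccc(O)c2C1=O)OC`) gives 63500 nM. Compound 3 thus stands level with compound 2, within the scatter, and on the weaker side of compound 1. Compound 4 (`CCC(O)(CC)CC(=O)O[C@H](CC=C(C)C)C1=CC(=O)c2c(O)ccc(O)c2C1=O`) has not yet been measured. It differs from compound 3 on an oxygen on a saturated carbon: (2-ethyl-2-hydroxybutyl)carbonyl in place of 2-methoxybutyl on an oxygen on a saturated carbon.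

Among the measured compounds shown here, only one measured step bears directly on this change: a 2.8-fold higher number from compound 1 to compound 3 (0.45 log units; beyond the scatter), a modest step in which 1-methoxypropyl took the place of 1-hydroxyethyl. In compound 4 the incoming (2-ethyl-2-hydroxybutyl)carbonyl again carries a hydrogen-bond donor, which the leaving 2-methoxybutyl lacks, and that points back toward compound 1. Against this, compound 2, which also has a carbonyl-bearing group on that oxygen, stays at 73500 nM. A shift no larger than the measured step therefore seems likely. The step expected is a 1.8-fold lower number from compound 3 to compound 4 (0.26 log units; within the scatter), leaning to the lower side. For compound 4 the estimate is 35000 nM, with an expected range from 15000 nM to 90000 nM.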

Compound 4, half-maximal inhibitory concentration: 52000 nM
Compound 4: the middle estimate sits 1.5-fold (0.17 log units) below what was measured; the measured number falls inside the stated range.
By their numbers in this assay, from the lowest: compound 1; then compounds 4, 3 and 2 (each within the scatter of the next).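

In this assay, (2-ethyl-2-hydroxybutyl)carbonyl in place of 2-methoxybutyl on an oxygen on a saturated carbon leaves the number within the scatter (a 1.2-fold lower number from compound 3 to compound 4 (0.09 log units; within the scatter)), so this larger group with its hydroxyl does not set compound 4 apart from compound 3. The change of 1-acetoxypentyl to 1-ethyl-1-hydroxypropyl, made on a saturated chain carbon bound to a carbonyl carbon, is also within the scatter (a 1.4-fold lower number from compound 2 to compound 4 (0.15 log units; within the scatter)), which places compound 2, compound 3 and compound 4 on one level, with compound 1 the only one of the four that goes against it. The step to compound 4 from compound 1 lies beyond the scatter, though it is modest (a 2.3-fold higher number from compound 1 to compound 4 (0.36 log units; beyond the scatter)), and since 2-hydroxypropyl and (2-ethyl-2-hydroxybutyl)carbonyl both hold a hydroxyl, a hydroxyl on this side chain does not by itself go with the lower number of compound 1.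

On these data alone, how an amine or a carboxylic acid on this side chain, or a longer chain ending in a hydroxyl, would read on this assay stays open. Nothing available explains why compound 1 stands apart from the other three.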